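The source may report more compounds than this note shows. Statements on the series, on what has been measured and on what is new or still open speak of the compounds shown alone.

Of the compounds shown here, two on the shared core have numbers so far. Compound 1 `CC(C)CC(=O)N1CCc2cc(CNC(=O)c3cccnc3)ccc21` gives 86% in an assay on HEK293 cells for inhibition of Indoleamine 2,3-dioxygenase 1 (Homo sapiens), tested at 10 uM (a higher number here means more inhibition at the concentration tested (going by the name of the read-out), a lower number less inhibition), and stands highest of the two. Compound 2 `CCC(=O)NCc1ccc2c(c1)CCN2C(=O)c1ccccc1` gives 41% in this assay, a gap to compound 1 that lies beyond the scatter. Compound 2 differs from compound 1 in more than one place at once, so the pair says only what its two values show and no single change can be read from it.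

Compound 3 `CC(C)CC(=O)N1CCc2cc(CNC(=O)c3cccs3)ccc21` has not yet been measured in this assay. It differs from compound 1 as follows: thiophen-2-yl in place of pyridin-3-yl on a carbonyl carbon. For the measured compounds named here, no measured pair carries this change, so its size is not known from the numbers at hand. A small fall from compound 1 is expected, a number 14 percentage points lower from compound 1 to compound 3 (beyond the scatter), with a fair chance that the step stays within the scatter. Compound 3 is estimated at 72%, within 45% to 92%.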

Compound 3, a percentage reported as inhibition, at one concentration (the size of the read-out at that concentration, not a potency): 100%
Compound 3: middle estimate off by 28 percentage points, on the low side; measured number outside the range, above it.
By their numbers in this assay, from the lowest: compound 2; then compound 1; then compound 3.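

For the compounds shown here, on the carbonyl carbon whose other neighbour is the amide-type nitrogen, thiophen-2-yl in place of pyridin-3-yl gives a number 14 percentage points higher from compound 1 to compound 3 (beyond the scatter) in this assay, the first change that can be read in one place. In this pair, the pyridine nitrogen is not needed to keep inhibition at the concentration tested: a five-membered aromatic ring with sulfur as its hetero atom serves at least as well here. Nothing at hand bears on why the step runs in this direction.

From the compounds shown here alone, compound 3 at 100% is a reading at one concentration, so its potency relative to compound 1 remains open. Also open, going by these compounds, is whether furan-2-yl, or a saturated ring such as cyclohexyl, would hold inhibition on the same carbonyl carbon.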